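This account rests on a few compounds, and the source may have more. Where it says the series, first, only, none or still open, it means among the compounds named here.

Of the compounds shown here, three on a shared core have been read in a functional assay on A-375 cells (Homo sapiens) for cytotoxicity, read by MTT assay; a higher number here means a weaker inhibitor, a lower number a stronger inhibitor. Compound 1 `C=CCOc1cc(/C=C/C(=O)c2ccc(OC)c3c2OC(C)(C)C=C3)ccc1OC` gives > 10000 nM, which is a limit of the assay and not a number. Compound 2 `COc1ccc(/C=C/C(=O)c2ccc(OC)c3c2OC(C)(C)C=C3)cc1OCCCN(C)C` gives 4100 nM. Compound 3 `CCC(=O)Oc1cc(/C=C/C(=O)c2ccc(OC)c3c2OC(C)(C)C=C3)ccc1OC` gives 240 nM, the lowest number of the set. The nearest numeric value belongs to compound 2, and the gap is a 17-fold lower number from compound 2 to compound 3 (1.23 log units; beyond the scatter). Against the limit reading, the comparison gives an at least 41-fold lower number from compound 1 to compound 3 (1.61 log units; beyond the scatter).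

Compound 4 `COc1ccc(/C=C/C(=O)c2ccc(OC)c3c2OC(C)(C)C=C3)cc1OC(=O)C1CC1` has not yet been measured. It differs from compound 3 as follows: cyclopropyl in place of ethyl on a carbonyl carbon. In other words, propanoyl gives way to cyclopropylcarbonyl, and the carbonyl on the oxygen stays.

The two large steps into compound 3, an at least 41-fold lower number from compound 1 to compound 3 (1.61 log units; beyond the scatter) and a 17-fold lower number from compound 2 to compound 3 (1.23 log units; beyond the scatter), both replace a group without a carbonyl on that oxygen by propanoyl. Among the measured compounds shown here, neither varies the acyl group itself, so no measured step tests this change directly. Compound 4 keeps the carbonyl that compound 3 carries at 240 nM, so no step beyond the scatter is expected in this assay, in either direction. The expected change is a 1.2-fold higher number from compound 3 to compound 4 (0.07 log units; within the scatter). For compound 4 the estimated value is 280 nM, with an expected range of 100 nM to 800 nM.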

Compound 4, half-maximal inhibitory concentration: 380 nM
The estimate for compound 4 lay 1.4-fold (0.13 log units) below the measured number, and the stated range covers the measured number.
By their numbers in this assay, from the lowest: compounds 3 and 4 (each within the scatter of the next); then compound 2. At a limit, above all of these: compound 1.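

Among the compounds shown, only this pair varies the acyl group on the oxygen while keeping the carbonyl, and in this assay replacing ethyl with cyclopropyl on the carbonyl carbon gives a 1.6-fold higher number from compound 3 to compound 4 (0.20 log units; within the scatter), so the two groups are not told apart at this position. The large gap between an acyl group and a group without a carbonyl on that oxygen now appears with a second acyl group, as replacing 3-(dimethylamino)propyl with cyclopropylcarbonyl gives an 11-fold lower number from compound 2 to compound 4 (1.03 log units; beyond the scatter). Replacing allyl with cyclopropylcarbonyl gives an at least 26-fold lower number from compound 1 to compound 4 (1.42 log units; beyond the scatter), and this step starts from a limit, not a number, for compound 1: the limit of > 10000 nM in this assay, at which 1 of the 4 values shown sits.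

As far as these compounds go, it remains open whether a longer chain such as hexanoyl, or an aromatic acyl group such as benzoyl, would stay level with propanoyl and cyclopropylcarbonyl on this oxygen. From the compounds shown here alone, it is also open whether a free hydroxyl or a dimethylcarbamoyl group there would read with the two acyl compounds or with compound 2, which would show how much of the gap depends on the ester itself.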